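Configuration change at the ring carbon: compound 3 to compound 4

This account rests on a few compounds, and the source may have more. Where it says the series, first, only, none or still open, it means among the compounds named here.

compound 1 `CN1CCC[C@H]1[C@@H]1COc2cc([N+](=O)[O-])ccc2O1` — in an assay on membranes from Cerebral cortex for displacement of a labelled ligand from Neuronal acetylcholine receptor; alpha4/beta2 (Rattus norvegicus), with a stated time of 5 min (a higher number here means a weaker inhibitor, a lower number a stronger inhibitor), compound 1 gives 46000 nM
compound 2 `CN1CCC[C@H]1[C@@H]1COc2cc(O)ccc2O1` — in this assay compound 2 gives 50000 nM
compound 3 `CN1CCC[C@H]1[C@H]1COc2cc(-c3ccccc3)ccc2O1` — in this assay compound 3 gives 92000 nM

Compound 3 gives the highest of the three numbers in this assay, but its gaps to compound 2 and to compound 1 are both within the scatter, so no order among the three can be claimed. Among the compounds with values here, the only single-point step measured so far, a 1.1-fold higher number from compound 1 to compound 2 (0.04 log units; within the scatter), is likewise within the scatter.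

Compound 4 `CN1CCC[C@H]1[C@@H]1COc2cc(-c3ccccc3)ccc2O1` is the next compound. It differs from compound 3 as follows: the two compounds have the same atoms and bonds and differ only in configuration as drawn: 1 of 2 stereo elements differ; a stereocentre at a saturated ring carbon is drawn S in compound 3 and R in compound 4. Within the data shown here, no measured step covers a change of configuration alone. Compound 1 and compound 2 carry the configuration drawn for compound 4 at that ring carbon, and their values in this assay sit within the scatter of compound 3; they carry other substituents, so they bear on the step only loosely. The expected step of a 1.5-fold lower number from compound 3 to compound 4 (0.19 log units; within the scatter) is therefore small, if anything toward a lower number, and not beyond the scatter. Compound 4 is estimated at 60000 nM in this assay, with an expected range from 20000 nM to 180000 nM.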

Compound 4, inhibition constant: 59000 nM
Compound 4: the middle estimate sits 1.0-fold (0.01 log units) above what was measured; low and high end bracket the measured number.
By their numbers in this assay, from the lowest: compounds 1, 2, 4 and 3 (each within the scatter of the next).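

Taken on its own in this assay, the configuration at the saturated ring carbon gives a 1.6-fold lower number from compound 3 to compound 4 (0.19 log units; within the scatter), so S and R at that centre cannot be told apart with phenyl on the aromatic carbon, and this reading concerns that one centre alone: the fact that compounds 3 and 4 differ only in the configuration as drawn. With the configuration drawn alike, phenyl in place of hydroxy gives a 1.2-fold higher number from compound 2 to compound 4 (0.07 log units; within the scatter) and phenyl in place of nitro gives a 1.3-fold higher number from compound 1 to compound 4 (0.11 log units; within the scatter), so nitro, hydroxy and phenyl at this position do not separate either. No step among these four compounds lies beyond the scatter, and neither a change of substituent nor a change of configuration has yet moved the number in a readable way.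

On these data alone, it remains open whether any other group at this position, such as an amine, a carboxylic acid or a longer chain, would give a step beyond the scatter. As far as these compounds go, the second stereocentre, drawn alike in all four compounds, also remains open.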